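Working notes: nitro to methoxy in the series

The source may hold more compounds than are shown below. What is called first, only, known or untested is meant among the compounds shown, and "the series" means these compounds.

Measured in a functional assay on TM4 cells (Mus musculus) for cytotoxicity, read by MTT assay, with a stated time of 72 h; a higher number here means a weaker inhibitor, a lower number a stronger inhibitor:
- compound 1 `Nc1nc(Nc2ccc(S(N)(=O)=O)cc2)sc1C(=O)c1cccnc1`: 13000 nM
- compound 2 `Nc1nc(Nc2ccc(S(N)(=O)=O)cc2)sc1C(=O)c1cccc([N+](=O)[O-])c1`: 4000 nM

Of the two measured compounds, compound 2 stands lower in this assay, at 4000 nM. The next compound is compound 3 `COc1cccc(C(=O)c2sc(Nc3ccc(S(N)(=O)=O)cc3)nc2N)c1`, which differs from compound 2 as follows: methoxy in place of nitro on an aromatic carbon. In words, this is methoxy in place of nitro on an aromatic carbon, meta to a large group, or 3-nitrophenyl to 3-methoxyphenyl.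

Among the measured compounds shown here, only one measured step bears on this change, and only indirectly: a 3.3-fold lower number from compound 1 to compound 2 (0.51 log units; beyond the scatter). It replaced pyridin-3-yl with 3-nitrophenyl on the same carbonyl carbon and was modest in size. For the measured compounds named here, no measured pair yet exchanges the nitro group itself, so the data give little guidance on direction. A step no larger than that modest one is therefore expected in this assay, quite possibly none beyond the scatter. The expected step is a 1.3-fold higher number from compound 2 to compound 3 (0.10 log units; within the scatter). Compound 3 is estimated at 5000 nM, with an expected range of 1500 nM to 15000 nM.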

Compound 3, half-maximal inhibitory concentration: 6400 nM
Beside the measured number, compound 3's estimate is 1.3-fold (0.11 log units) below it; the range from low to high includes it.
By their numbers in this assay, from the lowest: compounds 2 and 3 (each within the scatter of the next); then compound 1.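

In this assay, methoxy in place of nitro on the aromatic carbon meta to a large group gives a 1.6-fold higher number from compound 2 to compound 3 (0.20 log units; within the scatter), so this position accepts two quite different substituents, one with a nitrogen and one with a carbon, without a change that can be told from the scatter. The exchange of pyridin-3-yl for 3-methoxyphenyl on the carbonyl carbon gives a 2.0-fold lower number from compound 1 to compound 3 (0.31 log units; beyond the scatter), in the same direction as a 3.3-fold lower number from compound 1 to compound 2 (0.51 log units; beyond the scatter), so the lower number seen with compound 2 is no longer tied to the nitro group and holds for both substituted phenyl compounds among the three shown. Nothing on hand accounts for either step or for the tolerance at this position.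

Open, going by these compounds, is whether an unsubstituted phenyl would group with compound 2 and compound 3 or with compound 1, which would show whether the substituent matters at all. Also open, on these data alone, is how an amine, a carboxylic acid or a longer alkoxy chain at this position would read in this assay, and whether any of them would give a step beyond the scatter.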